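A Longer Chain and a Shared Core

The source may report more compounds than this note shows. Statements on the series, on what has been measured and on what is new or still open speak of the compounds shown alone.

Compound 1 `CCc1ccc(NC(=O)Nc2c(C(C)C)cccc2C(C)C)cc1` has the highest number of the three measured compounds; in an assay on isolated protein for inhibition of acyl-CoA:cholesterol acyltransferase (Oryctolagus cuniculus) (a lower number here means a stronger inhibitor, a higher number a weaker inhibitor), compound 1 gives 100 nM. Compound 2 `CCCCc1ccc(NC(=O)Nc2c(C(C)C)cccc2C(C)C)cc1` gives 29 nM in this assay, and compound 3 `CCCCCCCCCCc1ccc(NC(=O)Nc2c(C(C)C)cccc2C(C)C)cc1` gives 13 nM. Compound 4 `CCCCCCc1ccc(NC(=O)Nc2c(C(C)C)cccc2C(C)C)cc1` has not yet been measured. Among the compounds with values here, it differs from compound 1 by butyl in place of hydrogen on a saturated chain carbon, two bonds along the chain from an aromatic carbon, so the chain on compound 4 is longer than the one on compound 2 and shorter than the one on compound 3. Two measured steps from compound 1 bear on this change: lengthening the chain gave a 3.4-fold lower number from compound 1 to compound 2 (0.54 log units; beyond the scatter), and lengthening it further gave a 7.7-fold lower number from compound 1 to compound 3 (0.89 log units; beyond the scatter). Between the two longer chains there was also a 2.2-fold lower number from compound 2 to compound 3 (0.35 log units; beyond the scatter). Since butyl sits between ethyl and octyl in length, a lower number in this assay, beyond the scatter and between those two steps, is expected, meaning a 5.0-fold lower number from compound 1 to compound 4 (0.70 log units; beyond the scatter). Compound 4 is therefore estimated at 20 nM, with a range from 9 nM to 45 nM.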

Compound 4, half-maximal inhibitory concentration: 26 nM
The estimate for compound 4 lay 1.3-fold (0.11 log units) below the measured number, within the range that was stated.
By their numbers in this assay, from the lowest: compounds 3, 4 and 2 (each within the scatter of the next, the first and the last beyond it); then compound 1.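

In this assay the added butyl gives a 3.8-fold lower number from compound 1 to compound 4 (0.59 log units; beyond the scatter) and so adds a third longer chain at this place that stands clearly apart from compound 1. The earlier compounds shown here alone could be read as a steady fall in the number with each added length of chain, yet a 1.1-fold lower number from compound 2 to compound 4 (0.05 log units; within the scatter) and a 2.0-fold higher number from compound 3 to compound 4 (0.30 log units; within the scatter) both stay within the usual scatter. Compound 4 therefore cannot be told apart from either of the other two longer-chain compounds, even though a 2.2-fold lower number from compound 2 to compound 3 (0.35 log units; beyond the scatter) is just beyond the scatter, so the three form only a shallow slope.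

Still open, going by these compounds, is whether a chain longer than that of compound 3, or a chain carrying an amine or a carboxylic acid, would hold or change the number. No measurement shown accounts for this shallow slope.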